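Trading a hydroxy-methoxy ring for two methyl groups

A few compounds are considered here, and "the series" means these few. Any claim that something is new, unique, unknown or untested is made for them only; others in the source may bear on it.

Measured so far:
compound 1, `Oc1ccc2[nH]ncc2c1C(c1ccc(-c2nccs2)cc1)N1CCCCC1`, 340 nM
compound 2, `COc1ccc(C(Nc2cc(C)ccn2)c2ccc3cccnc3c2O)cc1O`, 150 nM
compound 3, `Cc1cc(C)c(C(Nc2ccccn2)c2ccc3cccnc3c2O)c(C)c1`, 190 nM

In an assay for inhibition of protein disulfide-isomerase (Homo sapiens), with a stated time of 1 h (on this read-out lower numbers stand for stronger inhibition and higher numbers for weaker inhibition), compound 2 gives the lowest of the three numbers. Compound 3 stands nearest to it; the gap between the two lies within the scatter of this assay, so no order between them can be claimed. Compound 1 is the furthest away, and its gap from compound 2 lies beyond the scatter.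

Compound 4, `Cc1ccnc(NC(c2cc(C)ccc2C)c2ccc3cccnc3c2O)c1`, has not yet been measured. It differs from compound 2 in one place: 2,5-dimethylphenyl in place of 3-hydroxy-4-methoxyphenyl on a saturated chain carbon bound to an aromatic carbon and a nitrogen on an aromatic ring. Compound 3 also carries a methyl-bearing ring without oxygen at the same position and reaches 190 nM, close to compound 2. On that basis the step from compound 2 to compound 4 is expected to be small, at most a modest move toward a higher number, and likely within the scatter. The expected value for compound 4 in this assay is 210 nM, with a range from 90 nM to 480 nM. This corresponds to an expected step of a 1.4-fold higher number from compound 2 to compound 4 (0.15 log units; within the scatter).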

Compound 4, half-maximal inhibitory concentration: > 40000 nM
Compound 4 gave a limit, no number; the forecaster's own chance of this, stated with the estimate: 3%; middle value at least 190-fold (2.27 log units) from the limit.
By their numbers in this assay, from the lowest: compounds 2, 3 and 1 (each within the scatter of the next, the first and the last beyond it). At a limit, above all of these: compound 4.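

Among the compounds shown here, the three earlier compounds offered no pair differing in one place, so this step is the first direct reading of the group on the saturated chain carbon bound to an aromatic carbon and a nitrogen on an aromatic ring. In this assay, putting 2,5-dimethylphenyl in place of 3-hydroxy-4-methoxyphenyl there gives an at least 260-fold higher number from compound 2 to compound 4 (2.42 log units; beyond the scatter), which shows that this position is far from indifferent to the change, at least with the rest of compound 2 held fixed. Compound 4 is reported only as a limit of the assay, so the true size of the step stays unknown: the limit of > 40000 nM in this assay, at which 1 of the 4 values shown sits.

The compounds shown do not tell whether the step follows the loss of the hydroxy group, the loss of the methoxy group or the arrival of the two methyl groups. A 3-hydroxyphenyl, a 4-methoxyphenyl or a plain phenyl at this place would begin to separate these.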